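The source may hold more compounds than are shown below. What is called first, only, known or untested is meant among the compounds shown, and "the series" means these compounds.

Among the measured compounds shown here, in a functional assay on HeLa cells (Homo sapiens) for cytotoxicity, read by WST assay, with a stated time of 48 h (on this read-out higher numbers stand for weaker inhibition and lower numbers for stronger inhibition), compound 1 `COc1ccc(/C=C/C[C@H]2C[C@@H]([C@@H](O)c3ccc(OC)c(OC)c3)CO[C@@H]2c2ccccc2)cc1OC` gives 17000 nM, which stands second highest among the three numbers measured so far. Compound 2 `COc1ccc(/C=C/C[C@@H]2C[C@@H]([C@@H](O)c3ccc(OC)c(OC)c3)CO[C@H]2c2ccccc2)cc1OC` gives 16100 nM, and compound 3 `Oc1cccc(/C=C/C[C@H]2C[C@@H]([C@@H](O)c3ccccc3)CO[C@@H]2c2ccccc2)c1` gives 18600 nM; all three numbers lie within the scatter of one another, so no order among them can be read. For the measured compounds named here, the only measured step between compounds that differ in one place, a 1.1-fold lower number from compound 1 to compound 2 (0.02 log units; within the scatter), rests on the fact that compounds 1 and 2 differ only in the configuration as drawn and does not involve the exchange of a group. Compound 4 `COc1ccc(/C=C/C[C@H]2C[C@@H]([C@@H](O)c3ccc(OC)c(OC)c3)CO[C@@H]2c2ccc(OC)c(OC)c2)cc1OC` carries the change (3,4-dimethoxyphenyl in place of phenyl on a saturated ring carbon). Going by the values given here, no measured step exchanges one aromatic group for another at that place, so the data give no direct guide for this change; they show only that every compound measured so far sits in the same narrow band. Compound 4 is therefore expected to stay in that band, and the step of no change at the digits printed from compound 1 to compound 4 (within the scatter) is not expected to go beyond the scatter in either direction. The estimate for compound 4 in this assay is 17000 nM, with a range from 8000 nM to 36000 nM.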

Compound 4, half-maximal inhibitory concentration: 23800 nM
Beside the measured number, compound 4's estimate is 1.4-fold (0.15 log units) below it; measured number inside the range.
By their numbers in this assay, from the lowest: compounds 2, 1, 3 and 4 (each within the scatter of the next).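

In this assay, among the compounds shown here, the only measured exchange of one aromatic group for another on the saturated ring carbon next to the ring oxygen gives a 1.4-fold higher number from compound 1 to compound 4 (0.15 log units; within the scatter). This shows that at this place, 3,4-dimethoxyphenyl in place of phenyl adds hydrogen-bond acceptors and more heavy atoms without taking the number beyond the scatter. For the compounds shown here, nothing measured so far offers a reason for the size of this step.

Going by these compounds, it remains open whether an amine or a carboxylic acid on the aromatic group at this place, or a cyclohexyl group in place of the aromatic group, would move the number beyond the scatter. The compounds shown also leave open whether 3,4-dimethoxyphenyl would give a similar result in the configuration drawn for compound 2.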